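Swapping methylsulfonyl for methylsulfanyl on the shared core

The source may report more compounds than this note shows. Statements on the series, on what has been measured and on what is new or still open speak of the compounds shown alone.

Compound 1 `Cn1c(-c2cccc(F)c2)nnc1S(C)(=O)=O` gives > 200 mg/kg as a limit
Compound 2 `Cn1c(-c2ccccc2)nnc1S(C)(=O)=O` gives > 200 mg/kg as a limit
Compound 3 `CSc1nnc(-c2ccc(C)cc2)n1C` gives > 100 mg/kg as a limit

In a functional assay on the whole organism for antagonist activity, with Mus musculus as the target (on this read-out lower numbers stand for an effect already at smaller amounts and higher numbers for an effect only at larger amounts of compound), compound 1 stands at > 200 mg/kg as a limit and not a number, and the two other measured values are limits too. Compound 4 `CSc1nnc(-c2cccc(F)c2)n1C` has not yet been measured. It differs from compound 1 by methylsulfanyl in place of methylsulfonyl on an aromatic carbon sets out what leaves and what enters. Among the compounds with values here, the only measured step is a step that the two limits leave unreadable from compound 1 to compound 2 with hydrogen in place of fluoro, and it rests on the limit of > 200 mg/kg in this assay, at which 2 of the 3 values shown sit, so it gives no size for this change. Within the data shown here, compound 3 gives > 100 mg/kg as a further limit and is the only measured compound carrying methylsulfanyl. In this assay a modest move towards a lower number is expected, on thin evidence, and the estimated size is an at least 2.0-fold lower number from compound 1 to compound 4 (0.30 log units; that floor lies within the scatter) in that direction. For compound 4 the expected value is 100 mg/kg with an estimated range from 25 mg/kg to 300 mg/kg. A plain limit may well be the outcome again.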

Compound 4, dose for half-maximal effect: > 200 mg/kg
Compound 4: no number, only a limit; the forecaster's own chance of this, stated with the estimate: 50%; at least 2.0-fold (0.30 log units) between middle value and limit.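

In this assay compound 4 gives > 200 mg/kg, a limit and not a number. Compound 1 gives > 200 mg/kg, also a limit, and the step between compound 1 and compound 4 cannot be read. The compounds shown leave open what dose any of them needs, and whether methylsulfanyl in place of methylsulfonyl changes it at all.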